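Ring-size change on the amine of compound 1

The source may report more compounds than this note shows. Statements on the series, on what has been measured and on what is new or still open speak of the compounds shown alone.

Three analogues share one core and have been measured in an assay on isolated protein for inhibition of cathepsin S (Homo sapiens); on this read-out lower numbers stand for stronger inhibition and higher numbers for weaker inhibition. Compound 1 `N#C[C@@]1(NC(=O)[C@@H](CC(=O)N2CCOCC2)CC2CCCCC2)CCN(C2CCCC2)C1` gives 75 nM. Compound 3 `N#CC1(NC(=O)[C@@H](CC(=O)N2CCOCC2)CC2CCCCC2)CC1` gives 135 nM, and compound 2 `N#C[C@H](CCc1ccccc1)NC(=O)[C@@H](CC(=O)N1CCOCC1)CC1CCCCC1` gives 171 nM. Compound 1 thus holds the lowest of the three numbers; its gap to compound 3 lies within the scatter, so no order between these two is claimed, while its gap to compound 2 lies beyond the scatter.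

The next compound in the series is compound 4 `N#C[C@@]1(NC(=O)[C@@H](CC(=O)N2CCOCC2)CC2CCCCC2)CCN(C2CCCCC2)C1`. It differs from compound 1 in one place: cyclohexyl in place of cyclopentyl on an amine nitrogen in a ring. Among the measured compounds shown here, no step between measured compounds speaks to this change; the only comparisons available concern the other end of the molecule.

With nothing in the measured set pointing either way, the step from compound 1 to compound 4 is expected to be small, at most on the edge of the scatter, in this assay: a 1.3-fold lower number from compound 1 to compound 4 (0.10 log units; within the scatter). Compound 4 is therefore estimated at 60 nM in this assay, with a range from 25 nM to 150 nM.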

Compound 4, half-maximal inhibitory concentration: 23 nM
Compound 4: the middle estimate sits 2.6-fold (0.42 log units) above what was measured; the measured number lies below the stated range.
By their numbers in this assay, from the lowest: compound 4; then compounds 1, 3 and 2 (each within the scatter of the next, the first and the last beyond it).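

In this assay, among the compounds shown here, the step of a 3.3-fold lower number from compound 1 to compound 4 (0.51 log units; beyond the scatter) comes with cyclohexyl in place of cyclopentyl on an amine nitrogen in a ring, the first reading at this position. The earlier compounds shown here gave no comparison here; this pair shows that the read-out responds at this position to a change from a five-membered to a six-membered carbon ring, by a step beyond the usual scatter. No supporting measurement bears on this result, so the step stands as an observation without an assigned cause.

Going by these compounds, the series rests here on one pair, so whether the trend carries on to a cycloheptyl ring remains open. An open-chain group such as isopropyl, or a phenyl ring, on the same nitrogen would show whether a carbon ring is needed at this position at all.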